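Thiourea aryl swap on the shared core

The source may report more compounds than this note shows. Statements on the series, on what has been measured and on what is new or still open speak of the compounds shown alone.

Compound 1 `NC(=O)c1c(NC(=O)c2ccccc2Cl)sc2c1CCN(Cc1cc(Cl)cc(Cl)c1)C2` gives 19600 nM in a functional assay on HeLa cells (Homo sapiens) for antiproliferative activity, with a stated time of 24 h; a higher number here means a weaker inhibitor, a lower number a stronger inhibitor. Compound 2 `Cc1ccccc1NC(=S)N1CCc2c(sc(NC(=O)c3ccccc3Cl)c2C(N)=O)C1` reaches only the limit > 50000 nM in this assay, not a number. Compound 3 `COc1ccc(NC(=S)N2CCc3c(sc(NC(=O)c4ccccc4Cl)c3C(N)=O)C2)cc1` gives 36400 nM in this assay, the highest of the two numbers shown; its nearest neighbour is compound 1 a 1.9-fold higher number from compound 1 to compound 3 (0.27 log units; within the scatter), while an at least 2.5-fold higher number from compound 1 to compound 2 (0.40 log units; beyond the scatter) and an at least 1.3-fold lower number from compound 2 to compound 3 (0.13 log units; that floor lies within the scatter) frame the thiourea pair. Compound 4 `NC(=O)c1c(NC(=O)c2ccccc2Cl)sc2c1CCN(C(=S)Nc1c(Cl)cccc1Cl)C2` differs from compound 3 only by 2,6-dichlorophenyl in place of 4-methoxyphenyl on an amide-type nitrogen. For the measured compounds named here, the single comparable step, an aryl swap on the thiourea nitrogen, is an at least 1.3-fold lower number from compound 2 to compound 3 (0.13 log units; that floor lies within the scatter), bounded by a limit (the limit of > 50000 nM in this assay, at which 1 of the 3 values shown sits), so no step beyond the scatter is expected in this assay: a 1.1-fold higher number from compound 3 to compound 4 (0.04 log units; within the scatter). Compound 4 is therefore estimated at 40000 nM, between 18000 nM and 90000 nM.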

Compound 4, half-maximal inhibitory concentration: 26500 nM
Estimate against measurement, compound 4: 1.5-fold (0.18 log units) above, and the stated range covers the measured number.
By their numbers in this assay, from the lowest: compounds 1, 4 and 3 (each within the scatter of the next). At a limit, above all of these: compound 2.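

Swapping 4-methoxyphenyl for 2,6-dichlorophenyl on the amide-type nitrogen gives no readable change in this assay, with a 1.4-fold lower number from compound 3 to compound 4 (0.14 log units; within the scatter), and the thiourea group of compound 4 likewise stays level with the group on the ring amine of the shared core, with a 1.4-fold higher number from compound 1 to compound 4 (0.13 log units; within the scatter). The step against 2-methylphenyl gives only a floor, with an at least 1.8-fold lower number from compound 2 to compound 4 (0.27 log units; that floor lies within the scatter). Compound 2 has no number, only a limit: the limit of > 50000 nM in this assay, at which 1 of the 4 values shown sits.

The measured numbers of compounds 1, 3 and 4 therefore show no aryl preference at this position. From the compounds shown here alone, whether a pyridyl ring, a carboxylic acid or an alkyl chain on this nitrogen would give a step beyond the scatter remains open.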